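From piperazin-1-yl to 4-propylpiperazin-1-yl on the shared core

This account rests on a few compounds, and the source may have more. Where it says the series, first, only, none or still open, it means among the compounds named here.

Of the compounds shown here, three on the shared core have been measured in a functional assay on A-375 cells (Homo sapiens) for cytotoxicity, read by MTT assay, with a stated time of 72 h; a higher number here means a weaker inhibitor, a lower number a stronger inhibitor. Compound 1 `CN(C)CCCCCn1c2c(c3ccccc31)C(=O)c1c[n+]([O-])c3ccccc3c1C2=O` gives 560 nM, compound 2 `O=C1c2c[n+]([O-])c3ccccc3c2C(=O)c2c1c1ccccc1n2Cc1cn(C[C@H](O)CO)nn1` gives 350 nM and compound 3 `O=C1c2c[n+]([O-])c3ccccc3c2C(=O)c2c1c1ccccc1n2CCCCN1CCNCC1` gives 460 nM. Compound 3 lies within the scatter of both others, so no order can be read among the three.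

The next compound is compound 4 `CCCN1CCN(CCCCn2c3c(c4ccccc42)C(=O)c2c[n+]([O-])c4ccccc4c2C3=O)CC1`. Its difference from compound 3 is propyl in place of hydrogen on an amine nitrogen in a ring. Among the measured compounds shown here, no measured step changes that nitrogen, so the evidence is only indirect. For the measured compounds named here, the steps that bear on it are changes to the group carried on the aromatic nitrogen: a 1.2-fold lower number from compound 1 to compound 3 (0.09 log units; within the scatter), a 1.3-fold higher number from compound 2 to compound 3 (0.12 log units; within the scatter) and a 1.6-fold lower number from compound 1 to compound 2 (0.20 log units; within the scatter). All three stay within the scatter, although the groups exchanged in them are large. On these three compounds, the readout in this assay has so far shown little response to that group. The data hold no direct test of a propyl group here, so the range is kept wide.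

No step beyond the scatter is expected, and the estimated step is a 1.2-fold lower number from compound 3 to compound 4 (0.06 log units; within the scatter). For compound 4 the expected value is 400 nM, with an estimated range of 190 nM to 850 nM.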

Compound 4, half-maximal inhibitory concentration: 870 nM
Estimate against measurement, compound 4: 2.2-fold (0.34 log units) below, outside the stated range (above it).
By their numbers in this assay, from the lowest: compounds 2, 3, 1 and 4 (each within the scatter of the next, the first and the last beyond it).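

Notes on the amine nitrogen in the ring: in this assay, this is the first direct reading at this position, and the step from hydrogen to propyl is a 1.9-fold higher number from compound 3 to compound 4 (0.28 log units; within the scatter), so the added propyl does not separate the two compounds. The first separation in the series appears only with an exchange of the whole group on the saturated chain carbon bound to the aromatic nitrogen, at a 2.5-fold higher number from compound 2 to compound 4 (0.40 log units; beyond the scatter), a modest step beyond the scatter, whereas the exchange of (dimethylamino)methyl for 4-propylpiperazin-1-yl gives a 1.6-fold higher number from compound 1 to compound 4 (0.19 log units; within the scatter) and stays within it. No supporting measurement on these compounds accounts for the values, so the result stands as a plain readout on cells.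

Going by these compounds, it remains open whether a methyl, a butyl or a 2-hydroxyethyl group on the same amine nitrogen would read with compound 3, with compound 4 or apart from both. An acetyl group at that nitrogen, or a longer chain linking the piperazine to the aromatic nitrogen, would also test whether the separation from compound 2 holds beyond this single pair.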